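This account rests on a few compounds, and the source may have more. Where it says the series, first, only, none or still open, it means among the compounds named here.

Three compounds have numbers in an ADME assay on microsomes from liver (Homo sapiens) for metabolic stability; a lower number here means slower removal, a higher number faster removal of the compound. Compound 1 `Cc1ccc2[nH]c(C(=O)N[C@H]3CN(S(=O)(=O)c4ccccc4)C[C@@H]3C(=O)N[C@@H]3CCCNC3)cc2c1` gives 3 mL.min-1.g-1, compound 2 `Cc1ccc2[nH]c(C(=O)N[C@H]3CCN(S(=O)(=O)c4ccccc4Cl)C[C@@H]3C(=O)N[C@H]3CCCNC3)cc2c1` gives 25 mL.min-1.g-1, and compound 3 `Cc1csc(C(=O)N[C@H]2CN(S(=O)(=O)c3ccccc3)C[C@@H]2C(=O)N[C@H]2CCCNC2)n1` gives 9.1 mL.min-1.g-1. Compound 3 thus holds the second highest of the three numbers, lying beyond the scatter from both of the others: lower than compound 2 and higher than compound 1.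

Compound 4 `O=C(N[C@H]1CN(S(=O)(=O)c2ccccc2)C[C@@H]1C(=O)N[C@H]1CCCNC1)c1nnc(-c2ccc(F)cc2)s1` has not yet been measured in this assay. It differs from compound 3 in the group on the carbonyl carbon: a group of 12 heavy atoms (8 carbon, 2 nitrogen, 1 fluorine, 1 sulfur; one five-membered aromatic ring with 3 hetero atoms, one six-membered aromatic ring of carbon only) in place of a group of 6 heavy atoms (4 carbon, 1 nitrogen, 1 sulfur; one five-membered aromatic ring with 2 hetero atoms), on a carbonyl carbon. The 4-methyl-1,3-thiazol-2-yl group leaves, and a larger group enters that also has a six-membered aromatic ring of carbon only.

Within the data shown here, no two measured compounds differ in one place only, so this expectation is loose. A moderate rise is expected, toward compound 2 at 25 mL.min-1.g-1, although compound 1 at 3 mL.min-1.g-1 leaves the direction uncertain. The expected step is a 2.2-fold higher number from compound 3 to compound 4 (0.34 log units; beyond the scatter). For compound 4 the estimated value is 20 mL.min-1.g-1, with an expected range from 8 mL.min-1.g-1 to 50 mL.min-1.g-1.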

Compound 4, intrinsic clearance in microsomes: 8.8 mL.min-1.g-1
Compound 4: middle estimate off by 2.3-fold (0.36 log units), on the high side; the measured number falls inside the stated range.
By their numbers in this assay, from the lowest: compound 1; then compounds 4 and 3 (each within the scatter of the next); then compound 2.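

In this assay, among these compounds, replacing the 4-methyl-1,3-thiazol-2-yl group on the carbonyl carbon with the larger group that also carries a six-membered aromatic ring of carbon only gives a 1.0-fold lower number from compound 3 to compound 4 (0.01 log units; within the scatter) in the first comparison of compounds that differ in one place. Among the compounds shown here, this place on the carbonyl carbon therefore accepts the extra heavy atoms, the second ring and the fluorine together with no change beyond the scatter, something the earlier compounds could not show. No measurement available here explains this result.

The entering group alters ring type, size and fluorine content all at once, so compound 3 and compound 4 cannot separate these features. As far as these compounds go, how an amine or a carboxylic acid in this place would read in this assay also remains open.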